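The source may report more compounds than this note shows. Statements on the series, on what has been measured and on what is new or still open speak of the compounds shown alone.

Three compounds built on one shared core were tested in a functional assay for agonist activity at G protein-coupled receptor 88 (Homo sapiens), read by HTRF and cAMP accumulation; a lower number here means that less compound is needed, a higher number that more compound is needed for the effect. Compound 1 `CC[C@H](C)[C@H](N)CN(C(=O)[C@@H]1C[C@H]1c1ccccc1)c1ccc(-c2ccc(C(F)(F)F)cc2)cc1` gives 340 nM. Compound 2 `CC[C@H](C)[C@H](N)CN(C(=O)[C@@H]1C[C@H]1c1ccccc1)c1ccc(-c2ccc(OC)cc2)cc1` gives 120 nM, and compound 3 `CC[C@H](C)[C@H](N)CN(C(=O)[C@@H]1C[C@H]1c1ccccc1)c1ccc(-c2ccc(Oc3ccccc3)cc2)cc1` gives 94 nM. Among these three, compound 3 has the lowest number, but its distance to compound 2 is within the scatter: a 1.3-fold lower number from compound 2 to compound 3 (0.11 log units; within the scatter). The two steps away from compound 1 were larger, a 2.8-fold lower number from compound 1 to compound 2 (0.45 log units; beyond the scatter) and a 3.6-fold lower number from compound 1 to compound 3 (0.56 log units; beyond the scatter).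

Compound 4 `CC[C@H](C)[C@H](N)CN(C(=O)[C@@H]1C[C@H]1c1ccccc1)c1ccc(-c2ccc(OC(F)(F)F)cc2)cc1` has not yet been measured. It differs from compound 3 by trifluoromethyl in place of phenyl on an oxygen on an aromatic ring. Among the compounds with values here, no measured step swaps exactly these two groups on this oxygen. The closest comparison is the exchange of methyl for phenyl on the same oxygen, a 1.3-fold lower number from compound 2 to compound 3 (0.11 log units; within the scatter), which stayed within the scatter. Compound 1 carries a trifluoromethyl directly on the ring and gives a higher number than the two oxygen-linked compounds, but that evidence is only indirect. The expected step is therefore small, a 1.6-fold higher number from compound 3 to compound 4 (0.20 log units; within the scatter), within the scatter. Compound 4 is estimated at 150 nM, in a range from 60 nM to 400 nM.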

Compound 4, half-maximal effective concentration: 170 nM
The estimate for compound 4 lay 1.1-fold (0.05 log units) below the measured number, within the range that was stated.
By their numbers in this assay, from the lowest: compounds 3, 2, 4 and 1 (each within the scatter of the next, the first and the last beyond it).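

In this assay the trifluoromethyl group on the oxygen on an aromatic ring cannot be told apart from phenyl (a 1.8-fold higher number from compound 3 to compound 4 (0.26 log units; within the scatter)) or from methyl (a 1.4-fold higher number from compound 2 to compound 4 (0.15 log units; within the scatter)). Within the data shown here, this oxygen has now carried three different groups, one of them a six-membered aromatic ring, and no step between them clears the scatter. Trifluoromethoxy in place of trifluoromethyl on the aromatic carbon also stays within the scatter (a 2.0-fold lower number from compound 1 to compound 4 (0.30 log units; within the scatter)), whereas the steps to methoxy and phenoxy from that same compound went beyond it.

From the compounds shown here alone, whether an amine or a carboxylic acid in place of the phenoxy would give a step beyond the scatter remains open. No measurement offers an explanation for any of these steps.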